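The compounds below may be only part of what the source reports. "The series", "measured", "known", "first", "only" and "open" are said of these compounds alone.

Working notes on the series

Two compounds have a number in an ADME assay on NCI-H460 cells (Homo sapiens) for cytotoxicity (a lower number here means a stronger inhibitor, a higher number a weaker inhibitor), so far. Compound 1 `COc1cc(O)cc(CCCCCCC/C=C/CCCCCc2cc(O)cc(O)c2)c1` gives 27000 nM in this assay. Compound 2 `Oc1cc2cc(c1)Oc1c(O)cc(cc1O)[C@H](O)CCCCCC/C=C/CCCCC2` gives 27900 nM in this assay; the two numbers lie within the scatter of each other, so compound 1 and compound 2 cannot be told apart on this read-out. Both compounds are weak inhibitors in this assay.

Compound 3 `Oc1cc(O)cc(CCCCC/C=C/CCCCCCCc2cc(O)cc(O)c2)c1` has not been measured in this assay. The difference from compound 1 to compound 3 is hydrogen in place of methyl on an oxygen on an aromatic ring. Among the measured compounds shown here, no step between measured compounds covers this kind of change, so there is no measured precedent for what a hydrogen in place of methyl on an oxygen on an aromatic ring does here.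

Given the weak number of compound 1 at 27000 nM, the expected step in this assay from compound 1 to compound 3 is small, a 1.1-fold lower number from compound 1 to compound 3 (0.03 log units; within the scatter), in either direction and likely not beyond the scatter. The estimate for compound 3 in this assay is 25000 nM, with a range from 10000 nM to 60000 nM.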

Compound 3, half-maximal inhibitory concentration: 27700 nM
Beside the measured number, compound 3's estimate is 1.1-fold (0.04 log units) below it; low and high end bracket the measured number.
By their numbers in this assay, from the lowest: compounds 1, 3 and 2 (each within the scatter of the next).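

The change from methoxy to hydroxy on an oxygen on an aromatic ring now has a measured step in this assay, a 1.0-fold higher number from compound 1 to compound 3 (0.01 log units; within the scatter). On this read-out, therefore, 3-hydroxy-5-methoxyphenyl and 3,5-dihydroxyphenyl cannot be told apart on the shared core, and the methyl on this oxygen can be exchanged for hydrogen with no difference that the assay resolves. This is a single pair, so it describes this position on this core only, and no information is available that would explain the result.

The compounds shown leave open whether a larger group on this oxygen, such as ethyl or benzyl, or an amine or a carboxylic acid in place of the hydroxy, would move the number in this assay beyond the scatter. Also open, going by these compounds, is whether a shorter or longer chain in the core of compound 1 would give a step beyond the scatter, and whether the same exchange of methyl for hydrogen would leave the number as unmoved on another core.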